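Extending the Side Chain on a Tail Flick Series

The source may hold more compounds than are shown below. What is called first, only, known or untested is meant among the compounds shown, and "the series" means these compounds.

Measured so far:
Compound 1, `C[C@H](NC(=O)CN(c1nc(Cl)nc2[nH]cnc12)C1CC1)C(=O)OCc1ccccc1`, gives 41.2% in a functional assay on the whole organism (Tail, strain ICR) with Mus musculus as the target, in the tail flick test, with a stated time of 30 min, at a dose of 25 umol/kg by the oral route; on this read-out higher numbers stand for a stronger effect at the one dose given and lower numbers for a weaker effect.
Compound 2, `C[C@@H](O)[C@H](NC(=O)CN(c1nc(Cl)nc2[nH]cnc12)C1CC1)C(=O)OCc1ccccc1`, gives 21.9% in this assay.

Compound 2 stands lowest of the two numbers; the one step shown is a number 19.3 percentage points lower from compound 1 to compound 2 (beyond the scatter). Compound 3, `O=C(CN(c1nc(Cl)nc2[nH]cnc12)C1CC1)N[C@@H](CCC(=O)OCc1ccccc1)C(=O)OCc1ccccc1`, carries the change (2-(benzyloxycarbonyl)ethyl in place of 1-hydroxyethyl on a saturated chain carbon bound to an amide-type nitrogen and a carbonyl carbon). Among the compounds with values here, no measured step matches this exchange; the only one available replaced methyl with 1-hydroxyethyl at the same place and lowered the read-out, so it bears on it only loosely. On that basis compound 3 is expected to move a number 11.1 percentage points higher from compound 2 to compound 3 (beyond the scatter), with wide uncertainty. The estimate for compound 3 in this assay is 33%, within 10% to 58%.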

Compound 3, a percentage reported as activity, at one dose (the size of the read-out at that dose, not a potency): 52.8%
The estimate for compound 3 lay 19.8 percentage points below the measured number; the range from low to high includes it.
By their numbers in this assay, from the lowest: compound 2; then compound 1; then compound 3.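

In this assay, 2-(benzyloxycarbonyl)ethyl in place of 1-hydroxyethyl gives a number 30.9 percentage points higher from compound 2 to compound 3 (beyond the scatter) and shows that a larger group at this place need not lower the read-out. Extending the methyl of the first compound to this same group gives a number 11.6 percentage points higher from compound 1 to compound 3 (beyond the scatter) and so the fall seen with 1-hydroxyethyl does not hold for every longer side chain. No measurement given here explains either step. From the compounds shown here alone, it remains open whether the benzyl ester carries this rise; a carboxylic acid or an amine at the end of the same chain would bear on that.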